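From cyano to nitro on the shared core

The source may report more compounds than this note shows. Statements on the series, on what has been measured and on what is new or still open speak of the compounds shown alone.

Compound 1 `CC(O)(CSc1ccc(S(F)(F)(F)(F)F)cc1)C(=O)Nc1ccc(C#N)c(C(F)(F)F)c1`: 30200 nM
Compound 2 `CC(O)(CSc1cccc(S(F)(F)(F)(F)F)c1)C(=O)Nc1ccc(C#N)c(C(F)(F)F)c1`: 31700 nM

Both values come from a functional assay on VCaP cells (Homo sapiens) for antiproliferative activity, read by propidium iodide staining, with a stated time of 96 h; a higher number here means a weaker inhibitor, a lower number a stronger inhibitor. For the measured compounds named here, compound 1 stands level with compound 2, the only other compound measured, since their two values lie within the scatter of each other. Compound 3 `CC(O)(CSc1ccc(S(F)(F)(F)(F)F)cc1)C(=O)Nc1ccc([N+](=O)[O-])c(C(F)(F)F)c1` keeps the rest of compound 1 and carries nitro in place of cyano on an aromatic carbon, ortho to a trifluoromethyl group: nitro in place of cyano on an aromatic carbon. Going by the values given here, no measured step shows the effect of this exchange, so no change beyond the scatter is expected in this assay, in either direction. The expected step is small, an estimated 1.1-fold lower number from compound 1 to compound 3 (0.03 log units; within the scatter) here. The estimate for compound 3 is 28000 nM, within an expected range from 11000 nM to 60000 nM.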

Compound 3, half-maximal inhibitory concentration: 10100 nM
Compound 3: middle estimate off by 2.8-fold (0.44 log units), on the high side; the whole stated range lies above it.
By their numbers in this assay, from the lowest: compound 3; then compounds 1 and 2 (each within the scatter of the next).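

In this assay, for the compounds shown here, the aromatic carbon ortho to a trifluoromethyl group proved sensitive to what it carries: the exchange gave a 3.0-fold lower number from compound 1 to compound 3 (0.48 log units; beyond the scatter), the first measured step here to pass beyond the scatter. The compounds shown thus establish this position as one where a change of group alters the antiproliferative reading. Nothing at hand accounts for the step. On these data alone, whether an amine or a carboxylic acid at this position would give a lower or a higher number remains open, as does whether nitro in place of cyano would give a similar step on compound 2.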